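Swapping an Ester Group: From tert-Butyl to Methyl

The source may report more compounds than this note shows. Statements on the series, on what has been measured and on what is new or still open speak of the compounds shown alone.

Measured so far:
- compound 1, `CC1=C(C(=O)OC(C)(C)C)C(c2cc([N+](=O)[O-])ccc2O)C2=C(CCC(C)(C)C2=O)N1`: in an assay for inhibition of Voltage-dependent L-type calcium channel subunit alpha-1C (Rattus norvegicus), read by patch clamp, tested at 10 uM (a higher number here means more inhibition at the concentration tested (going by the name of the read-out), a lower number less inhibition), compound 1 gives < 30%
- compound 2, `CC1=C(C(=O)OCC(C)C)C(c2cc([N+](=O)[O-])ccc2O)C2=C(CC(C)(C)CC2=O)N1`: in this assay compound 2 gives 30%

Of the compounds shown here, two have been measured, and both show only weak inhibition. For compound 1 the value is a limit of the assay rather than a number (the limit of < 30% in this assay, at which 1 of the 2 values shown sits). Compound 2 sits close by, so the two readings cannot be told apart, and no ordering between them can be claimed. Compound 1 therefore stands at the low end of what the assay reports, with no exact figure.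

The next compound, compound 3 `COC(=O)C1=C(C)NC2=C(C(=O)C(C)(C)CC2)C1c1cc([N+](=O)[O-])ccc1O`, is built from compound 1 by one change: methyl in place of tert-butyl on an oxygen next to a carbonyl group. Going by the values given here, nothing measured here tells how large an effect this change has, since no pair of measured compounds differs in this way. With both measured compounds weak, the expectation for compound 3 is a step from compound 1 of about a step that the limit leaves unreadable from compound 1 to compound 3 in this assay, meaning little movement beyond the scatter. Compound 3 is thus estimated at 25%, within a range from 5% to 50%.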

Compound 3, a percentage reported as inhibition, at one concentration (the size of the read-out at that concentration, not a potency): < 30%
Compound 3 gave a limit, no number; the forecaster's own chance of this, stated with the estimate: 50%; the middle value does not contradict the limit.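

In this assay compound 3 gives < 30%, which is a limit of the assay and not a number, and compound 1 is also recorded only as a limit, so no step between compound 1 and compound 3 can be read: the limit of < 30% in this assay, at which 2 of the 3 values shown sit.

The compounds shown leave open whether methyl in place of tert-butyl on an oxygen next to a carbonyl group changes inhibition at all, and by how much.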